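Removing the isopropyl from compound 3

The compounds below may be only part of what the source reports. "The series", "measured", "known", "first", "only" and "open" are said of these compounds alone.

The series is followed in an ADME assay (liver) for metabolic stability, with Liver microsome (Homo sapiens) as the target, using microsomes; a higher number here means faster removal of the compound, a lower number slower removal. Compound 1 `Cc1nc(N)c2c(n1)N(Cc1ccccc1)C(=O)C2` returns only a limit of the assay, giving < 7 mL.min-1.g-1. Compound 2 `O=c1[nH]n2c(O)nc(C3CC3)cc2c1Cc1ccccc1` likewise returns a limit, giving < 7 mL.min-1.g-1. Compound 3 `CC(C)c1cc2c([nH]c(=O)n2Cc2ccccc2)c(N)n1` also gives only a limit, namely < 7 mL.min-1.g-1. For the measured compounds named here, no steps between measured compounds that differ in one place are available, so nothing in this assay separates the three; all share (the limit of < 7 mL.min-1.g-1 in this assay, at which 3 of the 3 values shown sit), and compound 3 stands at the same limit as the other two rather than at a number.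

Compound 4 `Nc1nccc2c1[nH]c(=O)n2Cc1ccccc1` is yet to be measured in this assay. It differs from compound 3 by hydrogen in place of isopropyl on an aromatic carbon. Going by the values given here, with compound 1, compound 2 and compound 3 all at the limit, there is no measured step from which the size of this change can be read. The loss of the isopropyl is expected to leave the value at or near the limit, so the step that the limit leaves unreadable from compound 3 to compound 4 is expected to be none beyond the scatter. For compound 4 the estimate is 5 mL.min-1.g-1, within 2 mL.min-1.g-1 to 10 mL.min-1.g-1.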

Compound 4, intrinsic clearance in microsomes in the Liver microsome assay: < 7 mL.min-1.g-1
Compound 4: a limit, no number; the forecaster's own chance of this, stated with the estimate: 70%; the middle value is on the limit's open side.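

In the Liver microsome assay compound 3 gives only a limit, < 7 mL.min-1.g-1. In the Liver microsome assay compound 4 also gives only a limit, < 7 mL.min-1.g-1. So no step between them can be read in the Liver microsome assay: the limit of < 7 mL.min-1.g-1 in the Liver microsome assay, at which 4 of the 4 values shown sit.

In a physicochemical assay for lipophilicity, measured as octanol-water partition, at pH 7.4 (on this read-out lower numbers stand for lower lipophilicity and higher numbers for higher lipophilicity), compound 3 gives 3.1 and compound 4 gives 1.9. The compounds shown leave open how hydrogen in place of isopropyl acts on intrinsic clearance, as none of them gives a number there, even with the physicochemical assay showing a number 1.20 log units lower from compound 3 to compound 4 (beyond the scatter).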